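Shortening the Ethoxy Chain on a Biaryl Amide Agonist

The source may report more compounds than this note shows. Statements on the series, on what has been measured and on what is new or still open speak of the compounds shown alone.

Compound 1, `CCc1ccc(-c2ccc(N(C[C@@H](N)[C@@H](C)CC)C(=O)[C@@H]3C[C@H]3c3ccccc3)cc2)cc1`: 44 nM
Compound 2, `CCOc1ccc(-c2ccc(N(C[C@@H](N)[C@@H](C)CC)C(=O)[C@@H]3C[C@H]3c3ccccc3)cc2)cc1`: 90 nM

Of the compounds shown here, two have been measured in a functional assay for agonist activity at G protein-coupled receptor 88 (Homo sapiens), read by HTRF and cAMP accumulation; a lower number here means that less compound is needed, a higher number that more compound is needed for the effect. Compound 1 gives 44 nM in this assay, while compound 2 gives 90 nM. For the measured compounds named here, compound 2 thus stands highest of the two numbers, and the single measured step, a 2.0-fold higher number from compound 1 to compound 2 (0.31 log units; beyond the scatter), separates it from compound 1; that step came with ethoxy in place of ethyl on an aromatic carbon.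

Compound 3, `CC[C@H](C)[C@H](N)CN(C(=O)[C@@H]1C[C@H]1c1ccccc1)c1ccc(-c2ccc(OC)cc2)cc1`, differs from compound 2 by hydrogen in place of methyl on a saturated chain carbon bound to an oxygen on an aromatic ring. Going by the values given here, no measured step removes a carbon from the alkoxy chain, so nothing bears directly on this change. Among the compounds with values here, the only step available, the exchange of ethyl for ethoxy, was modest, and a change that merely trims the same group by one carbon has no measured counterpart. The step from compound 2 to compound 3 in this assay is therefore expected to be small, a 1.1-fold higher number from compound 2 to compound 3 (0.05 log units; within the scatter), most likely within the scatter. Compound 3 is expected to give about 100 nM in this assay, within a range from 45 nM to 220 nM.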

Compound 3, half-maximal effective concentration: 120 nM
The estimate for compound 3 lay 1.2-fold (0.08 log units) below the measured number; low and high end bracket the measured number.
By their numbers in this assay, from the lowest: compound 1; then compounds 2 and 3 (each within the scatter of the next).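

Cutting ethoxy to methoxy gave a 1.3-fold higher number from compound 2 to compound 3 (0.12 log units; within the scatter) in this assay, so the two alkoxy groups on this aromatic carbon cannot be told apart by this measurement, and the length of the chain, across these two members, leaves no readable mark. Methoxy in place of ethyl gave a 2.7-fold higher number from compound 1 to compound 3 (0.44 log units; beyond the scatter), which, like a 2.0-fold higher number from compound 1 to compound 2 (0.31 log units; beyond the scatter), lies beyond the scatter, so among these three compounds both alkoxy groups give a higher number than ethyl, with no exception, and the new step is the larger of the two only as printed, not as a separate trend between the alkoxy groups. Nothing available explains why the alkoxy pair and the ethyl compound part in this way.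

Going by these compounds, whether a longer chain such as propoxy, or a hydroxy group or an amine on the same aromatic carbon, would keep the number where the alkoxy pair stands or bring it towards that of compound 1 remains open. The three compounds also share the rest of the core, so they cannot say whether these steps would hold on a different core.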